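This account rests on a few compounds, and the source may have more. Where it says the series, first, only, none or still open, it means among the compounds named here.

Measured in a functional assay on SK-N-SH cells (Homo sapiens) for inhibition, read by MTT assay, with a stated time of 72 h, tested at 30 uM; a lower number here means less inhibition of growth, a higher number more inhibition of growth at the concentration tested:

Compound 1 `C=CCc1ccc(OCc2cn(-c3ccc(C#N)cc3)nn2)c(O)c1`: 37.5%
Compound 2 `C#CCOc1ccc(CC=C)cc1O`: 11.8%
Compound 3 `C=CCc1cc(O)c(O)c(CN2CCC(CO)CC2)c1`: 21.9%

Compound 1 stands highest of these three in this assay. Compound 3 and compound 2 both fall lower, each by more than the usual scatter, and compound 2 lies furthest away.

The next compound to be tested, compound 4 `C=CCc1ccc(OCc2cn(-c3ccc(Br)cc3)nn2)c(O)c1`, keeps the core of compound 1 and differs from it in one place. It carries bromo in place of cyano on an aromatic carbon, para to a large group, so that 4-cyanophenyl becomes 4-bromophenyl (bromo in place of cyano on an aromatic carbon).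

Among the measured compounds shown here, no two measured compounds differ in only one place, so the data offer no measured step to show how large such an exchange might be. Compound 2 and compound 3 differ from compound 1 in much more than this one group and give little guidance. With the rest of the structure unchanged, the reference remains compound 1 at 37.5%, and no step beyond the scatter is expected in either direction. The estimated change is a step of a number 2.5 percentage points higher from compound 1 to compound 4 (within the scatter), and this small size is only an expectation. In this assay, compound 4 is expected at 40%, with an estimated range of 24% to 58%.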

Compound 4, percent growth inhibition at one concentration: 38.3%
Compound 4: middle estimate off by 1.7 percentage points, on the high side; measured number inside the range.
By their numbers in this assay, from the lowest: compound 2; then compound 3; then compounds 1 and 4 (each within the scatter of the next).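

Among the compounds shown here, the exchange of cyano for bromo on an aromatic carbon, para to a large group, gives the first measured step at this position: in this assay it reads as a number 0.8 percentage points higher from compound 1 to compound 4 (within the scatter). The 4-cyanophenyl of compound 1 and the 4-bromophenyl of compound 4 therefore cannot be told apart here, even though the cyano brings two heavy atoms, a triple bond and a hydrogen-bond acceptor, and the bromo a single heavy atom and no acceptor; at this position, in this one exchange, dropping that counted acceptor comes with no step beyond the scatter. Nothing available explains why the two groups read alike.

As far as these compounds go, it remains open whether a group of a different kind at this carbon, such as an amine or a carboxylic acid, would stay level with compound 1 and compound 4 or move away from them. From the compounds shown here alone, it is also open whether any group is needed here at all, a question that a plain phenyl ring with only hydrogen on this carbon could answer.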